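Removing the Fluoro Group from the Phenoxy Ring Again

This account rests on a few compounds, and the source may have more. Where it says the series, first, only, none or still open, it means among the compounds named here.

Three compounds have been measured in an assay on HEK-293T cells for inhibition of diacylglycerol lipase-alpha (Homo sapiens), read by colorimetric assay; on this read-out lower numbers stand for stronger inhibition and higher numbers for weaker inhibition:

compound 1, `O=C(N1CCCCC1COc1ccc(F)cc1)n1ncc(C(O)(c2ccc(F)cc2)c2ccc(F)cc2)n1`, gives 5.01 nM
compound 2, `O=C(N1CCCCC1COc1ccccc1)n1ncc(C(O)(c2ccc(F)cc2)c2ccc(F)cc2)n1`, gives 5.01 nM
compound 3, `O=C(N1CCCCC1COc1ccc(F)cc1)n1ncc(C(O)(c2ccccc2)c2ccccc2)n1`, gives 6.31 nM

Compound 1 and compound 2 differ in a single place, (hydrogen in place of fluoro on an aromatic carbon), and this change made no change at the digits printed from compound 1 to compound 2 (within the scatter). Compound 3 carries the same core as compound 1 on one side but differs from it elsewhere; the difference between the two cores is not broken down here. Compound 3 stands at the highest of the three numbers, yet its gap to compound 1 and to compound 2 is within the scatter, so nothing can be said about an order among the three.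

Compound 4, `O=C(N1CCCCC1COc1ccccc1)n1ncc(C(O)(c2ccccc2)c2ccccc2)n1`, has not been measured. It differs from compound 3 by hydrogen in place of fluoro on an aromatic carbon, which is the same change already seen from compound 1 to compound 2: the group that leaves, the group that enters and the place where it sits are described in the same words for both pairs. Because that earlier change produced no change at the digits printed from compound 1 to compound 2 (within the scatter), the step from compound 3 to compound 4 is expected to be of the same small size, a 1.0-fold lower number from compound 3 to compound 4 (0.00 log units; within the scatter), and this expectation rests on that single earlier pair alone. Compound 4 is therefore estimated at 6.3 nM in this assay, with a plausible range from 3 nM to 13 nM.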

Compound 4, half-maximal inhibitory concentration: 7.94 nM
For compound 4 the middle estimate is 1.3-fold (0.10 log units) below the measured one, within the range that was stated.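

In this assay, going by these compounds alone, hydrogen in place of fluoro on the phenoxy ring gave a 1.3-fold higher number from compound 3 to compound 4 (0.10 log units; within the scatter), so this second pair, like the first, shows no step that can be told apart from the scatter. Set beside the earlier step, the change reads the same on the two cores, which differ in whether the two phenyl groups on the carbinol carbon carry fluoro: the same change on two cores in this assay, no change at the digits printed (within the scatter) from compound 1 to compound 2 and a 1.3-fold higher number (0.10 log units; within the scatter) from compound 3 to compound 4, 1.3-fold (0.10 log units) apart, within the scatter of two such steps This shows that, on these two cores, going from 4-fluorophenoxy to phenoxy leaves the number within the scatter, but it rests on two pairs only, and with neither step beyond the scatter it does not show that the change has any effect of its own, nor that the same result would hold on a core outside these four compounds.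

The compounds shown carry only fluoro or hydrogen at this place on the phenoxy ring, so it remains open how a chloro, methoxy or nitrile group there would read in this assay. On these data alone, it is also open whether the same flat result would hold if the phenoxymethyl group gave way to a longer chain or an amine, or if the hydroxyl group on the carbinol carbon were replaced by hydrogen.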